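Amide variation in a chemokine receptor binding series

This account rests on a few compounds, and the source may have more. Where it says the series, first, only, none or still open, it means among the compounds named here.

Measured so far in an assay on MDA-MB-231 cells for binding affinity to C-X-C chemokine receptor type 4 (Homo sapiens), read by immunofluorescence and microscopy, with stated times of 10 min and 30 min; on this read-out higher numbers stand for an effect only at larger amounts of compound and lower numbers for an effect already at smaller amounts:
compound 1, `COc1ccc(C(=O)NCc2ccc(CNS(=O)(=O)c3ccc(C)cc3)cc2)cc1`: 100 nM
compound 2, `O=C(NCc1ccc(CNS(=O)(=O)c2ccccc2)cc1)c1cccnc1`: 10 nM

Compound 2 gives the lower of the two numbers; compound 1 sits far higher, and that gap is beyond the scatter. Compound 1 and compound 2 differ in more than one place, so no single-point step can be read from this pair.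

Compound 3, `O=C(NCc1ccc(CNS(=O)(=O)c2ccccc2)cc1)c1ccccc1Cl`, has not yet been measured in this assay. Relative to compound 2 the change is 2-chlorophenyl in place of pyridin-3-yl on a carbonyl carbon. For the measured compounds named here, no measured pair in the set isolates a change on the carbonyl carbon, so the data do not fix the direction of this step. The expected step is modest, most likely within the scatter or a small rise in the number, estimated as a 2.0-fold higher number from compound 2 to compound 3 (0.30 log units; within the scatter). For compound 3 the estimated value is 20 nM, with a range from 5 nM to 80 nM.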

Compound 3, effective concentration (reported as EC, without a stated level of effect): 10 nM
Compound 3: the middle estimate sits 2.0-fold (0.30 log units) above what was measured, within the range that was stated.
By their numbers in this assay, from the lowest: compounds 2 and 3 (each within the scatter of the next); then compound 1.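

In this assay, for the compounds shown here, 2-chlorophenyl in place of pyridin-3-yl on a carbonyl carbon gives no change at the digits printed from compound 2 to compound 3 (within the scatter), the first step that can be read at a single place. At this position, therefore, the ring nitrogen of pyridin-3-yl is not needed to hold the number: a ring of carbon only, bearing chlorine and counted with no hydrogen-bond acceptor, serves as well in this pair. No supporting measurement bears on why the number holds.

As far as these compounds go, whether this position also accepts a group other than an aromatic ring, such as a piperidine amine, a carboxylic acid or a longer alkyl chain, remains open. The number of compound 1 cannot yet be assigned to any one place, as that compound differs from both others in more than one place.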